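Compound 2 to compound 4: a longer piperazine side chain

A few compounds are considered here, and "the series" means these few. Any claim that something is new, unique, unknown or untested is made for them only; others in the source may bear on it.

In a functional assay on A-375 cells (Homo sapiens) for cytotoxicity, read by MTT assay, with a stated time of 72 h (a lower number here means a stronger inhibitor, a higher number a weaker inhibitor), compound 2 `O=C1c2c[n+]([O-])c3ccccc3c2C(=O)c2c1c1ccccc1n2CCCCN1CCNCC1` gives 460 nM, within the scatter of compound 1 `CN(C)CCCCCn1c2c(c3ccccc31)C(=O)c1c[n+]([O-])c3ccccc3c1C2=O` at 560 nM and of compound 3 `O=C1c2c[n+]([O-])c3ccccc3c2C(=O)c2c1c1ccccc1n2Cc1cn([C@H]2C[C@H](O)[C@@H](CO)O2)nn1` at 390 nM. Compound 2 therefore holds no distinct place among the three numbers. Compound 4 `CN1CCN(CCCCCCn2c3c(c4ccccc42)C(=O)c2c[n+]([O-])c4ccccc4c2C3=O)CC1` carries 2-(4-methylpiperazin-1-yl)ethyl in place of piperazin-1-yl on a saturated chain carbon, four bonds along the chain from an aromatic nitrogen. Within the data shown here, the one measured step that bears on this is a 1.2-fold lower number from compound 1 to compound 2 (0.09 log units; within the scatter), a change at the same place that stays within the scatter. Compound 3 has a very different side group, yet its value also stays within the scatter of compound 2. Among the measured compounds shown here, no measured pair isolates the added methyl or the added chain length. No step beyond the scatter is therefore expected in this assay, and no direction can be called. The expected change is a 1.1-fold lower number from compound 2 to compound 4 (0.03 log units; within the scatter) as a working estimate. For compound 4 the estimated value is 430 nM with an expected range of 190 nM to 950 nM as its limits.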

Compound 4, half-maximal inhibitory concentration: 630 nM
The estimate for compound 4 lay 1.5-fold (0.17 log units) below the measured number, within the range that was stated.
By their numbers in this assay, from the lowest: compounds 3, 2, 1 and 4 (each within the scatter of the next).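

In this assay the exchange of piperazin-1-yl for 2-(4-methylpiperazin-1-yl)ethyl gives a 1.4-fold higher number from compound 2 to compound 4 (0.14 log units; within the scatter) and so adds to the earlier picture: on a saturated chain carbon, four bonds along the chain from an aromatic nitrogen, this position accepts both the longer group and the loss of the hydrogen-bond donor without a step beyond the scatter. The comparison with the dimethylamino chain gives a 1.1-fold higher number from compound 1 to compound 4 (0.05 log units; within the scatter) and also stays within the scatter, so compound 1, compound 2 and compound 4 cannot be ordered. No supporting measurement accounts for these values.

The added methyl and the added chain length remain unseparated in this step. From the compounds shown here alone, whether a morpholine or a carboxylic acid at the chain end, or a much shorter chain, would give a step beyond the scatter remains open.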